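Second chloro added to compound 2: expected effect

The source may report more compounds than this note shows. Statements on the series, on what has been measured and on what is new or still open speak of the compounds shown alone.

Two compounds of the series have been run in a functional assay on SK-MEL-2 cells (Homo sapiens) for cytotoxicity, read by sulforhodamine B assay, with a stated time of 48 h; on this read-out lower numbers stand for stronger inhibition of growth and higher numbers for weaker inhibition of growth. Compound 1 `ClCc1ccccc1Cn1cnc2c(Cl)nc(Cl)nc21` gives 4360 nM in this assay. Compound 2 `ClCc1ccc(Cn2cnc3ncnc(Cl)c32)cc1` is known only by a limit of this assay. In this assay compound 2 gives > 100000 nM, which is a limit and not a number. Going by these compounds, this places compound 2 at the limit of > 100000 nM in this assay, at which 1 of the 2 values shown sits, so its true position on the scale is unknown beyond that point. Within the data shown here, no pair of the measured compounds differs in one place, so no measured step is available.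

Compound 3 `ClCc1ccc(Cn2cnc3nc(Cl)nc(Cl)c32)cc1` is not yet measured. It differs from compound 2 by chloro in place of hydrogen on an aromatic carbon, the new group sitting on an aromatic carbon of a six-membered aromatic ring with 2 nitrogen, between two ring nitrogen atoms. Compound 1 carries the same pair of chloro groups on its core and gives 4360 nM. Compound 2, without the second chloro, is known only by a limit of this assay. On this basis the step from compound 2 to compound 3 is expected to go toward stronger inhibition of growth, estimated as an at least 5.0-fold lower number from compound 2 to compound 3 (0.69 log units; beyond the scatter). Compound 3 is therefore expected to give about 20000 nM, with a likely range from 4000 nM to 100000 nM.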

Compound 3, concentration for total growth inhibition: 2690 nM
Estimate against measurement, compound 3: 7.4-fold (0.87 log units) above; measured number below the stated range.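

In this assay, the aromatic carbon between two ring nitrogen atoms proves to be a position where one added atom changes the read-out strongly: chloro in place of hydrogen gives an at least 37-fold lower number from compound 2 to compound 3 (1.57 log units; beyond the scatter). Among these compounds, this is the first measured step, and it links a compound with a measured value to one without. Compound 2 is known only by a limit of the assay, > 100000 nM, and the size of the step has a lower bound and no known upper end because compound 2 stands at that limit: the limit of > 100000 nM in this assay, at which 1 of the 3 values shown sits.

A single step with one entering group cannot show whether the gain belongs to chloro itself or would also appear with another group on the same carbon, such as an amine, a methoxy group or a methyl group. It also leaves open whether the step would hold with the other chloro on the shared core replaced, for instance by an amine, since both compounds of this step carry that chloro unchanged.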